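Removing the nitro group from compound 1

A few compounds are considered here, and "the series" means these few. Any claim that something is new, unique, unknown or untested is made for them only; others in the source may bear on it.

compound 1 `CC1(C)C2CCC1(C)C(OC(=O)/C=C/c1ccc(O)c(O)c1[N+](=O)[O-])C2`: 52900 nM
compound 2 `O=C(/C=C/c1cc(O)c(O)c([N+](=O)[O-])c1)OCCc1ccccc1`: 11400 nM
compound 3 `O=C(/C=C/c1ccc(O)c(O)c1[N+](=O)[O-])OCCc1ccccc1`: 8700 nM

All three values come from a functional assay on A549 cells (Homo sapiens) for cytotoxicity, read by MTT assay; on this read-out higher numbers stand for weaker inhibition and lower numbers for stronger inhibition. Compound 1 stands highest at 52900 nM, and its gaps to the other two both lie beyond the scatter. Compound 2 at 11400 nM and compound 3 at 8700 nM lie within the scatter of each other.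

Compound 4 `CC1(C)C2CCC1(C)C(OC(=O)/C=C/c1ccc(O)c(O)c1)C2` has not yet been measured. It keeps the core of compound 1 but has hydrogen in place of nitro on an aromatic carbon. For the measured compounds named here, all three measured compounds carry the nitro group, so no measured pair shows this change directly. The expectation is therefore loose. With compound 1 at 52900 nM, the top of the measured numbers, a moderate step towards a lower number in this assay is expected, and it may barely clear the scatter. The expected change is a 2.1-fold lower number from compound 1 to compound 4 (0.33 log units; beyond the scatter). The estimate for compound 4 is 25000 nM, with an expected range from 8000 nM to 70000 nM.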

Compound 4, half-maximal inhibitory concentration: 19500 nM
Compound 4: middle estimate off by 1.3-fold (0.11 log units), on the high side; the range from low to high includes it.
By their numbers in this assay, from the lowest: compounds 3, 2 and 4 (each within the scatter of the next, the first and the last beyond it); then compound 1.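

In this assay, replacing the nitro group with hydrogen, on the aromatic carbon ortho to a hydroxy group and ortho to a large group, gives a 2.7-fold lower number from compound 1 to compound 4 (0.43 log units; beyond the scatter). For the compounds shown here, this is the first pair in which the core of compound 1 stays fixed and only this position changes, and it shows that the nitro group is not needed for activity on this core, since its removal gives a modest step towards stronger inhibition. Nothing available explains why the number falls with this change.

Going by these compounds, whether the same change would give a similar step in compound 3, which carries the nitro group with a different ester part, remains open. Also open, on these data alone, is where an amine or a nitrile on this aromatic carbon would fall relative to compound 1 and compound 4.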